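Chloro for Methyl Across Two Amide Cores

The source may hold more compounds than are shown below. What is called first, only, known or untested is meant among the compounds shown, and "the series" means these compounds.

Compound 1 `Cc1ccc(C(CCN(C)C)NC(=O)C#Cc2ccccc2)cc1` gives 3090 nM in a functional assay on NIH3T3 cells for agonist activity at Urotensin-2 receptor (Homo sapiens), with a stated time of 5 days; a lower number here means that less compound is needed, a higher number that more compound is needed for the effect. Compound 2 `CN(C)CCC(NC(=O)C#Cc1ccccc1)c1ccc(Cl)cc1` differs from it by chloro in place of methyl on an aromatic carbon, and in this assay compound 2 gives 398 nM, so that a 7.8-fold lower number from compound 1 to compound 2 (0.89 log units; beyond the scatter). Compound 3 `Cc1ccc(C(CCN(C)C)NC(=O)/C=C/c2ccc(C(F)(F)F)cc2)cc1` carries a different core; the difference between the two cores is not broken down here. In this assay compound 3 gives 437 nM, which lies within the scatter of compound 2. Compound 4 `CN(C)CCC(NC(=O)/C=C/c1ccc(C(F)(F)F)cc1)c1ccc(Cl)cc1` has not yet been measured; it differs from compound 3 by chloro in place of methyl on an aromatic carbon, the same change as between compound 1 and compound 2. For compound 4 the expected step is a 4.0-fold lower number from compound 3 to compound 4 (0.60 log units; beyond the scatter). This expectation rests on the measured step of a 7.8-fold lower number from compound 1 to compound 2 (0.89 log units; beyond the scatter), which was seen on a different core, so a somewhat smaller step is anticipated. Compound 4 is therefore estimated at 110 nM, between 30 nM and 400 nM.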

Compound 4, half-maximal effective concentration: 129 nM
Compound 4: the middle estimate sits 1.2-fold (0.07 log units) below what was measured, and the stated range covers the measured number.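

The change from 4-methylphenyl to 4-chlorophenyl again gives a lower number in this assay, with a 3.4-fold lower number from compound 3 to compound 4 (0.53 log units; beyond the scatter), so the direction of the step holds on the second core. The two steps cannot be told apart in size: the same change on two cores in this assay, a 7.8-fold lower number (0.89 log units; beyond the scatter) from compound 1 to compound 2 and a 3.4-fold lower number (0.53 log units; beyond the scatter) from compound 3 to compound 4, 2.3-fold (0.36 log units) apart, within the scatter of two such steps. This supports carrying the change between these two cores only, and it shows neither what lies behind the step nor that it would hold on any other core.

The compounds shown leave open what a fluoro, a methoxy or a nitrile in place of the chloro would give on either core. They also leave open whether the step would persist with a primary amine in place of the dimethylamino group, or with a longer chain leading to it.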